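Carbamoyl on the outer phenyl ring of a carbamate FAAH inhibitor

This account rests on a few compounds, and the source may have more. Where it says the series, first, only, none or still open, it means among the compounds named here.

Measured compounds:
compound 1, `CC(=O)NCCN(C)c1cccc(OCCCCNC(=O)Oc2cccc(-c3ccccc3)c2)c1`, 1.45 nM
compound 2, `CC(=O)NCCN(C)c1cccc(OCCCCCCNC(=O)Oc2cccc(-c3ccccc3)c2)c1`, 1.34 nM

Two measured compounds share one core and differ only in the length of the chain between the core and the carbamate. In an assay (brain, strain Wistar) for inhibition of Fatty-acid amide hydrolase 1 (Rattus norvegicus), read by scintillation counting, with a stated time of 30 min (a lower number here means a stronger inhibitor, a higher number a weaker inhibitor), compound 1 gives 1.45 nM, and in this assay compound 2 gives 1.34 nM. Compound 2 has the lower of the two numbers, but the gap to compound 1 lies within the scatter, so the two cannot be told apart.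

Compound 3, `CC(=O)NCCN(C)c1cccc(OCCCCCCNC(=O)Oc2cccc(-c3cccc(C(N)=O)c3)c2)c1`, keeps the longer chain of compound 2 and adds one group: carbamoyl in place of hydrogen on an aromatic carbon. Going by the values given here, no measured pair shows this change, so its size is unknown here. The expectation is a step of at most modest size, more likely downward than upward, and quite possibly no step beyond the scatter, given a 1.3-fold lower number from compound 2 to compound 3 (0.13 log units; within the scatter). In this assay compound 3 is expected to give 1 nM, between 0.3 nM and 3.5 nM.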

Compound 3, half-maximal inhibitory concentration: 0.43 nM
Estimate against measurement, compound 3: 2.3-fold (0.37 log units) above; measured number inside the range.
By their numbers in this assay, from the lowest: compound 3; then compounds 2 and 1 (each within the scatter of the next).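

The outer phenyl ring responds to substitution in a way the chain change between compound 1 and compound 2 did not: in this assay, carbamoyl in place of hydrogen gives a 3.1-fold lower number from compound 2 to compound 3 (0.49 log units; beyond the scatter), a modest step but one beyond the scatter. This shows that a hydrogen on this aromatic carbon, meta to a large group, can give way to a group of three heavy atoms without the number rising; here it falls. Nothing measured here bears on what lies behind this step.

From the compounds shown here alone, the step rests on a single pair, so it remains open whether carbamoyl has the same effect on the chain of compound 1. Going by these compounds, it also remains open whether a nitrile, a carboxylic acid or an aminomethyl group at this place would give a similar step.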